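The source may report more compounds than this note shows. Statements on the series, on what has been measured and on what is new or still open speak of the compounds shown alone.

Working notes on the series. Compound 2 `Cc1cc(S(N)(=O)=O)ccc1NC(=O)COc1ccc(F)cc1Oc1ccc2ccccc2c1Br` gives 39500 nM in an ADME assay on C8166 cells (Homo sapiens) for cytotoxicity, read by MTT assay; on this read-out higher numbers stand for lower toxicity in this test and lower numbers for higher toxicity in this test. Compound 1 `Cc1cc(S(N)(=O)=O)ccc1NC(=O)COc1ccc(Cl)cc1Oc1ccc2ccccc2c1Br` gives 48100 nM in this assay, so that the step of a 1.2-fold higher number from compound 2 to compound 1 (0.09 log units; within the scatter) made by the change chloro in place of fluoro on an aromatic carbon stays within the scatter. Compound 3 `Cc1cc(S(N)(=O)=O)ccc1NC(=O)COc1ccc(F)cc1Oc1ccc2cc(C#N)ccc2c1` reaches only a limit of the test, > 395000 nM, in this assay. The step of an at least 10-fold higher number from compound 2 to compound 3 (1.00 log units; beyond the scatter) thus rests on the change 6-cyanonaphthalen-2-yl in place of 1-bromonaphthalen-2-yl on an oxygen on an aromatic ring and on the limit (the limit of > 395000 nM in this assay, at which 1 of the 3 values shown sits). Compound 4 `Cc1cc(S(N)(=O)=O)ccc1NC(=O)COc1ccc(Cl)cc1Oc1ccc2cc(C#N)ccc2c1` is not yet measured. It differs from compound 3 by chloro in place of fluoro on an aromatic carbon, the same change as from compound 2 to compound 1, on the same place in the words of both descriptions. Since the earlier step of a 1.2-fold higher number from compound 2 to compound 1 (0.09 log units; within the scatter) stayed within the scatter, the step that the limit leaves unreadable from compound 3 to compound 4 is expected to be likewise small, and compound 4 is expected near 450000 nM, between 200000 nM and 1000000 nM, most likely again reported only as a limit.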

Compound 4, half-maximal cytotoxic concentration: > 383000 nM
Compound 4: a limit, no number; the forecaster's own chance of this, stated with the estimate: 75%; the middle value lies beyond the limit too.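

On the core of compound 1, 6-cyanonaphthalen-2-yl in place of 1-bromonaphthalen-2-yl gives an at least 7.9-fold higher number from compound 1 to compound 4 (0.90 log units; beyond the scatter) in this assay, so the direction seen on the core of compound 2 carries over to this second core. Set side by side, the two steps agree in direction, but their sizes cannot be compared: the same change on two cores in this assay, an at least 10-fold higher number (1.00 log units; beyond the scatter) from compound 2 to compound 3 and an at least 7.9-fold higher number (0.90 log units; beyond the scatter) from compound 1 to compound 4; the limit leaves it open whether they differ. Compound 4 gives > 383000 nM, a limit and not a number, and the step between compound 3 and compound 4 cannot be read.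

The compounds shown do not separate the entry of the nitrile from the loss of the bromo, as both change in one step. Also open, as far as these compounds go, is whether an amine or a carboxylic acid in place of the nitrile would give a similar step.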